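From 2-fluorobenzyl to 2,3-difluorobenzyl on compound 3

The source may report more compounds than this note shows. Statements on the series, on what has been measured and on what is new or still open speak of the compounds shown alone.

In a functional assay on A-375 cells (Homo sapiens) for activation, with a stated time of 3 days (on this read-out higher numbers stand for an effect only at larger amounts of compound and lower numbers for an effect already at smaller amounts), compound 1 (`O=C(Nc1ccc(-c2cscn2)cc1)C1CCCN(S(=O)(=O)c2ccc(F)c(F)c2)C1`) gives > 20000 nM as a limit of the assay and not a number. Compound 2 (`O=C(NC1CCCN(Cc2ccc(F)c(F)c2)C1)c1ccc(-c2cscn2)cc1`) gives > 20000 nM and this too is a limit. Within the data shown here, compound 3 (`O=C(Nc1ccc(-c2cscn2)cc1)C1CCCN(Cc2ccccc2F)C1`) gives 7000 nM as the only actual number in the set.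

Compound 4 (`O=C(Nc1ccc(-c2cscn2)cc1)C1CCCN(Cc2cccc(F)c2F)C1`) carries 2,3-difluorobenzyl where compound 3 carries 2-fluorobenzyl. The change is fluoro in place of hydrogen on an aromatic carbon, counted as fluoro in place of hydrogen on an aromatic carbon and placed ortho to a fluoro group and meta to a large group.

Among the measured compounds shown here, no measured pair differs in one place only, so the expectation rests on compound 3 at 7000 nM and on the change itself. In this assay a step within the usual scatter is expected, with no firm direction. The expected size is a 1.2-fold lower number from compound 3 to compound 4 (0.07 log units; within the scatter) in this estimate. For compound 4 the estimated value is 6000 nM with an expected range of 2000 nM to 18000 nM on this read-out.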

Compound 4, half-maximal effective concentration: 10000 nM
Beside the measured number, compound 4's estimate is 1.7-fold (0.22 log units) below it, within the range that was stated.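

In this assay the move from 2-fluorobenzyl to 2,3-difluorobenzyl gives a 1.4-fold higher number from compound 3 to compound 4 (0.15 log units; within the scatter) and so leaves the read-out unchanged within the scatter. Among these compounds, this is the first step that can be read on numbers, and it shows that a second fluoro, ortho to a fluoro group and meta to a large group, is accommodated without a loss that stands clear of the scatter. The set now holds two measured values on one benzyl series instead of one.

Open, from the compounds shown here alone, is whether a larger group in this place, such as methoxy or trifluoromethyl, or a charged one such as an amine, would move the number beyond the scatter. Steps to the other compounds cannot be read, and what they would show stays open as well: the limit of > 20000 nM in this assay, at which 2 of the 4 values shown sit.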